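Carboxymethyl for trifluoromethyl: an untested change on an inactive series

A few compounds are considered here, and "the series" means these few. Any claim that something is new, unique, unknown or untested is made for them only; others in the source may bear on it.

Measured compounds and their values:
- Compound 1 `CC1CC/C(=N\Nc2cccc(Cl)c2)c2ncc(C(=O)O)c(=O)n21` gives > 100 umol/kg in a functional assay on the whole organism for inhibition, with Rattus norvegicus as the target; on this read-out lower numbers stand for an effect already at smaller amounts and higher numbers for an effect only at larger amounts of compound.
- Compound 2 `CC1CC/C(=N\Nc2ccccc2O)c2ncc(C(=O)O)c(=O)n21` gives > 100 umol/kg in this assay.
- Compound 3 `CC1CC/C(=N\Nc2ccc(C(F)(F)F)cc2)c2ncc(C(=O)O)c(=O)n21` gives > 1000 umol/kg in this assay.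

None of these three numbers is a measured value: each is a limit of the assay, meaning no inhibition was seen up to that dose. Compound 3 therefore stands at a limit, as do the two other compounds, so no ordering among them can be read. Going by the values given here, the one change that can be compared, a step that the two limits leave unreadable from compound 1 to compound 2, is also unreadable, since both ends are limits (the limit of > 100 umol/kg in this assay, at which 2 of the 3 values shown sit).

Compound 4 `CC1CC/C(=N\Nc2ccc(CC(=O)O)cc2)c2ncc(C(=O)O)c(=O)n21` differs from compound 3 by carboxymethyl in place of trifluoromethyl on an aromatic carbon.

Among the compounds with values here, no measured step touches this position or this pair of groups, so nothing here points to a change in either direction beyond the scatter. Given that compound 3 sits at the higher limit (the limit of > 1000 umol/kg in this assay, at which 1 of the 3 values shown sits), compound 4 is expected to stay near it: the estimated step is a number no higher from compound 3 to compound 4 (the limit leaves the size open). For compound 4 the estimate in this assay is 1000 umol/kg, with a range from 300 umol/kg to 3000 umol/kg, and most likely the assay will again report only a limit.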

Compound 4, dose for 50% inhibition: > 100 umol/kg
Compound 4 ended at the assay's limit; the forecaster's own chance of this, stated with the estimate: 80%; the middle value lies beyond the limit too.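

In this assay compound 4 gives > 100 umol/kg as a limit, not a number. Compound 3 gives > 1000 umol/kg as a limit too. Going by these compounds alone, with a limit at both ends, no step between compound 3 and compound 4 can be read. The compounds shown leave open at what dose in this assay any of them would give inhibition, if at all.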